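Sulfonyl for Carbonyl on the Ring Nitrogen of Compound 3

The source may hold more compounds than are shown below. What is called first, only, known or untested is meant among the compounds shown, and "the series" means these compounds.

In an assay on HEK293 cells for positive allosteric modulation of metabotropic glutamate receptor 5 (Homo sapiens), read by FLIPR, with a stated time of 1 h (on this read-out lower numbers stand for an effect already at smaller amounts and higher numbers for an effect only at larger amounts of compound), compound 3 `O=C(C1CCCC1)N1CCc2nc(C#Cc3ccccc3)sc2C1` gives 19 nM, the lowest of the two numbers shown. Compound 1 `CN1CCc2nc(C#Cc3ccccc3)sc2C1` gives 34 nM in this assay, the step of a 1.8-fold lower number from compound 1 to compound 3 (0.25 log units; within the scatter). Compound 2 `CC(C)CN1CCc2nc(C#Cc3ccccc3)sc2C1` reaches only the assay limit > 10000 nM in this assay. The steps of an at least 290-fold higher number from compound 1 to compound 2 (2.46 log units; beyond the scatter) and an at least 520-fold lower number from compound 2 to compound 3 (2.72 log units; beyond the scatter) show that substituents at this position can matter greatly, and their limit is described by the limit of > 10000 nM in this assay, at which 1 of the 3 values shown sits. Compound 4 `O=S(=O)(C1CC1)N1CCc2nc(C#Cc3ccccc3)sc2C1` carries cyclopropylsulfonyl in place of cyclopentylcarbonyl on an amine nitrogen in a ring. Within the data shown here, no measured step exchanges an acyl for a sulfonyl here; only the step from compound 1 to compound 3, within the scatter, bears on the group size. The expected step is a 2.1-fold higher number from compound 3 to compound 4 (0.32 log units; beyond the scatter), with no clear direction. Compound 4 is thus estimated at 40 nM, between 10 nM and 250 nM.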

Compound 4, half-maximal effective concentration: > 10000 nM
Compound 4: only a limit was reported; the forecaster's own chance of this, stated with the estimate: 10%; at least 250-fold (2.39 log units) between middle value and limit.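

In this assay, the exchange of cyclopentylcarbonyl for cyclopropylsulfonyl on the ring nitrogen is not tolerated, a change the earlier acyl and alkyl examples did not reveal: an at least 520-fold higher number from compound 3 to compound 4 (2.72 log units; beyond the scatter), and an at least 290-fold higher number from compound 1 to compound 4 (2.46 log units; beyond the scatter). Compound 4 gives > 10000 nM, which is a limit of the assay. The step between compound 2 and compound 4 cannot be read, and two different groups on this nitrogen now end at the limit: the limit of > 10000 nM in this assay, at which 2 of the 4 values shown sit.

Compound 4 changes the carbonyl to a sulfonyl and the five-membered ring to a three-membered ring together, and the compounds shown do not separate these two changes. A cyclopropylcarbonyl or cyclopentylsulfonyl group on the same nitrogen would separate them.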